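Amide Variation on a Dimethoxyindane Acid Scaffold

A few compounds are considered here, and "the series" means these few. Any claim that something is new, unique, unknown or untested is made for them only; others in the source may bear on it.

Compound 1, `COc1cc2c(cc1OC)C(CC(=O)O)CC2`: 26.7%
Compound 2, `CCN(CC)C(=O)CC1CCc2cc(OC)c(OC)cc21`: 16.7%

Of the compounds shown here, two have been measured in a functional assay on the whole organism (strain Wistar) for inhibition, with Rattus norvegicus as the target, read by paw edema, with stated times of 60 min and 24 h, at a dose of 100 mg/kg by the oral route; on this read-out lower numbers stand for less inhibition and higher numbers for more inhibition at the one dose given (going by the name of the read-out). Compound 1 `COc1cc2c(cc1OC)C(CC(=O)O)CC2` gives 26.7%. Within the data shown here, compound 2 `CCN(CC)C(=O)CC1CCc2cc(OC)c(OC)cc21` gives 16.7%, the lower of the two numbers, with compound 1 as its only neighbour; the step of a number 10 percentage points lower from compound 1 to compound 2 (within the scatter), in which diethylamino replaces hydroxy on the carbonyl carbon, lies within the scatter, so the two values cannot be told apart.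

Compound 3 `CCCNC(=O)CC1CCc2cc(OC)c(OC)cc21` has not yet been measured. It differs from compound 2 in one place: propylamino in place of diethylamino on a carbonyl carbon. Among the measured compounds shown here, the one measured step bears on it only loosely, since it concerns the change from acid to amide rather than a change between two amides, and it was a number 10 percentage points lower from compound 1 to compound 2 (within the scatter), within the scatter. There is therefore no ground to expect a step beyond the scatter in this assay in either direction for compound 3. The expected step is a number 3.3 percentage points higher from compound 2 to compound 3 (within the scatter). Compound 3 is estimated at 20% in this assay, with a range from 5% to 35%.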

Compound 3, a percentage reported as inhibition, in the whole organism at one dose (the size of the read-out at that dose, not a potency): 26.7%
Estimate against measurement, compound 3: 6.7 percentage points below; the measured number falls inside the stated range.
By their numbers in this assay, from the lowest: compounds 2, 1 and 3 (each within the scatter of the next).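

Among these compounds, at the carbonyl carbon of the shared core, propylamino in place of diethylamino, with 1 hydrogen-bond donor entering where the leaving group has 0, gives a number 10 percentage points higher from compound 2 to compound 3 (within the scatter) in this assay, so this first comparison between two amides shows no step that can be told from the scatter. Set against the acid, propylamino in place of hydroxy gives no change at the digits printed from compound 1 to compound 3 (within the scatter), so at this place neither amide can be told apart from the acid, and the hydroxy, diethylamino and propylamino groups all lie within the scatter of one another at the single dose given. No measurement is available that would account for these numbers.

As far as these compounds go, whether a longer chain such as butylamino, a cyclic amine such as piperidine, or an unsubstituted amino group on the carbonyl carbon would give a step beyond the scatter remains open. From the compounds shown here alone, what a change to the methoxy groups of the shared core would do in this read-out also remains open, as does how these compounds would compare at any other dose.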